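Replacing the Piperidine Amide of Compound 3

This account rests on a few compounds, and the source may have more. Where it says the series, first, only, none or still open, it means among the compounds named here.

Going by the values given here, compound 3 `Cn1cc(-c2nn(Cc3ccc(C(=O)N4CCCCC4)cc3)c(=O)c3ccccc23)cn1` gives 67400 nM in a functional assay on A549 cells (Homo sapiens) for antiproliferative activity, read by MTT assay, with a stated time of 72 h (on this read-out lower numbers stand for stronger inhibition and higher numbers for weaker inhibition), the second highest of the three numbers known. Compound 2 `Cc1noc(C)c1-c1nn(Cc2ccc(C(=O)N3CCCCC3)cc2)c(=O)c2ccccc12` gives 86200 nM, and the step of a 1.3-fold lower number from compound 2 to compound 3 (0.11 log units; within the scatter) lies within the scatter. Among the compounds with values here, compound 1 `Cn1cc(Nc2nn(Cc3ccc(C(=O)NC4CCCCC4)cc3)c(=O)c3ccccc23)cn1` gives 6800 nM, a far lower number, but it differs from compound 3 in more than one place, so no single step can be drawn from it. Compound 4 `Cn1cc(-c2nn(Cc3ccc(C(=O)NC4CC(C)(C)N([O])C(C)(C)C4)cc3)c(=O)c3ccccc23)cn1` differs from compound 3 in one place: a group of 12 heavy atoms (9 carbon, 2 nitrogen, 1 oxygen; one six-membered non-aromatic ring with 1 hetero atom) in place of a group of 6 heavy atoms (5 carbon, 1 nitrogen; one six-membered non-aromatic ring with 1 hetero atom), on a carbonyl carbon. Within the data shown here, no measured step bears directly on this change; the only amide variation among the measured compounds, between compound 1 and compound 3, is entangled with a second change. Compound 4 is therefore expected to give 40000 nM, within 10000 nM to 150000 nM, an estimated step of a 1.7-fold lower number from compound 3 to compound 4 (0.23 log units; within the scatter).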

Compound 4, half-maximal inhibitory concentration: 37300 nM
Compound 4: middle estimate off by 1.1-fold (0.03 log units), on the high side, and the stated range covers the measured number.
By their numbers in this assay, from the lowest: compound 1; then compounds 4, 3 and 2 (each within the scatter of the next, the first and the last beyond it).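

Going by these compounds alone, until now the measured single steps touched only the aromatic carbon, and this is the first to change the group on the carbonyl carbon. In this assay, the group of 12 heavy atoms, with 1 hydrogen-bond donor and 1 hydrogen-bond acceptor, takes the place of piperidin-1-yl with a 1.8-fold lower number from compound 3 to compound 4 (0.26 log units; within the scatter), so this change leaves the read-out within the scatter. Nothing measured here speaks to why the number holds.

Open, from the compounds shown here alone, is how a morpholin-4-yl group or a plain primary amide would read on this carbonyl carbon. Also open, going by these compounds, is how the cyclohexylamino group of compound 1 would read on the core of compound 3.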